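The source may hold more compounds than are shown below. What is called first, only, known or untested is meant among the compounds shown, and "the series" means these compounds.

Measured so far in an assay on isolated protein for inhibition of Fatty-acid amide hydrolase 1 (Rattus norvegicus), with a stated time of 3 h; a higher number here means a weaker inhibitor, a lower number a stronger inhibitor:
compound 1 `O=C(NCCCCc1ccccc1)n1cccn1` — 290 nM
compound 2 `Cc1cnn(C(=O)NCCCCc2ccccc2)c1` — 550 nM

Compound 2 stands alongside compound 1 in this assay: the step of a 1.9-fold higher number from compound 1 to compound 2 (0.28 log units; within the scatter) falls within the scatter, so the two are not separated. Compound 3 `N#Cc1cnn(C(=O)NCCCCc2ccccc2)c1` differs from compound 2 by cyano in place of methyl on an aromatic carbon. Among the measured compounds shown here, no measured step exchanges methyl for cyano; the only step available, a 1.9-fold higher number from compound 1 to compound 2 (0.28 log units; within the scatter), concerns hydrogen against methyl and itself lies within the scatter, so it gives no direction for the cyano change. The step of a 1.6-fold lower number from compound 2 to compound 3 (0.20 log units; within the scatter) is therefore expected to be modest, with its direction open. Compound 3 is expected near 350 nM. Its range is estimated from 80 nM to 1500 nM.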

Compound 3, inhibition constant: 42 nM
Beside the measured number, compound 3's estimate is 8.3-fold (0.92 log units) above it, outside the stated range (below it).
By their numbers in this assay, from the lowest: compound 3; then compounds 1 and 2 (each within the scatter of the next).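

In this assay this position on the shared core proves responsive: cyano in place of methyl gives a 13-fold lower number from compound 2 to compound 3 (1.12 log units; beyond the scatter) and stands clear of the scatter, whereas methyl in place of hydrogen did not separate compound 1 and compound 2. Cyano in place of hydrogen gives a 6.9-fold lower number from compound 1 to compound 3 (0.84 log units; beyond the scatter) as well, so compound 3 stands apart from both earlier compounds. Open, on these data alone, is whether trifluoromethyl, a carboxylic acid or an amine on this carbon would match cyano, and whether the step persists with a longer chain. Nothing available explains this change.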